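Phenoxymethyl triazoles on A549 cells: a chloro addition

This account rests on a few compounds, and the source may have more. Where it says the series, first, only, none or still open, it means among the compounds named here.

Compound 1, `O=[N+]([O-])c1ccc(Cn2cc(COc3ccccc3)nn2)cc1`: in an ADME assay on A549 cells (Homo sapiens) for inhibition, read by MTT assay, with a stated time of 48 h (on this read-out lower numbers stand for stronger inhibition of growth and higher numbers for weaker inhibition of growth), compound 1 gives > 100 ug/mL, a limit of the assay.
Compound 2, `Clc1ccc(Cn2cc(COc3ccccc3)nn2)cc1`: compound 2 gives > 100 ug/mL, again a limit.
Compound 3, `Brc1ccc(Cn2cc(COc3ccccc3)nn2)cc1`: compound 3 gives > 100 ug/mL, also a limit.

Compound 1 therefore stands nowhere on a scale, only at a limit, and the same holds for the whole set, since all three values sit at the limit of > 100 ug/mL in this assay, at which 3 of the 3 values shown sit. The steps a step that the two limits leave unreadable from compound 1 to compound 2, a step that the two limits leave unreadable from compound 1 to compound 3 and a step that the two limits leave unreadable from compound 2 to compound 3 are consequently unreadable.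

Compound 4, `O=[N+]([O-])c1ccc(Cn2cc(COc3ccc(Cl)cc3)nn2)cc1`, differs from compound 1 by chloro in place of hydrogen on an aromatic carbon. For the measured compounds named here, none of the measured steps touches this group; they exchange the nitro, chloro and bromo on the other ring, and none of them could be read. No step beyond the scatter is expected in this assay. Compound 4 is expected to give about 150 ug/mL, most likely between 60 ug/mL and 400 ug/mL. The expected step is a step that the limit leaves unreadable from compound 1 to compound 4.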

Compound 4, concentration for 50% growth inhibition: > 100 ug/mL
Compound 4: no number, only a limit (the forecaster's own chance of this, stated with the estimate: 85%); the middle value is on the limit's open side.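

For the compounds shown here, compound 4 gives > 100 ug/mL, a limit, so no step from compound 1 to compound 4 can be read: the limit of > 100 ug/mL in this assay, at which 4 of the 4 values shown sit. The compounds shown leave open whether a change on either ring brings any of them within the readable range of this assay.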